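The source may report more compounds than this note shows. Statements on the series, on what has been measured and on what is new or still open speak of the compounds shown alone.

Series of esters built on a shared core, all tested in a functional assay on A549 cells (Homo sapiens) for cytotoxicity, read by MTT assay, with a stated time of 24 h, tested at 10 uM; on this read-out lower numbers stand for a stronger effect and higher numbers for a weaker effect at the one concentration tested.

Compound 1 `CCCCCCCCCOC(=O)CCC(=O)N1CCN(CCCOc2cc3c(Nc4ccc(F)c(Cl)c4)ncnc3cc2OC)CC1` is the shortest chain in the set; in this assay compound 1 gives 90%. Compound 2 `CCCCCCCCCCOC(=O)CCC(=O)N1CCN(CCCOc2cc3c(Nc4ccc(F)c(Cl)c4)ncnc3cc2OC)CC1` carries methyl in place of hydrogen on a saturated chain carbon, nine bonds along the chain from an oxygen next to a carbonyl group; in this assay compound 2 gives 95.7%. The step of a number 5.7 percentage points higher from compound 1 to compound 2 (within the scatter) is within the scatter. Compound 3 `CCCCCCCCCCCCCCCOC(=O)CCC(=O)N1CCN(CCCOc2cc3c(Nc4ccc(F)c(Cl)c4)ncnc3cc2OC)CC1` carries hexyl in place of hydrogen on a saturated chain carbon, nine bonds along the chain from an oxygen next to a carbonyl group; in this assay compound 3 gives 92%. The step of a number 2 percentage points higher from compound 1 to compound 3 (within the scatter) and the step of a number 3.7 percentage points lower from compound 2 to compound 3 (within the scatter) are both within the scatter, so the three measured numbers cannot be put in order.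

Compound 4 `CCCCCCCCCCCCCCCCOC(=O)CCC(=O)N1CCN(CCCOc2cc3c(Nc4ccc(F)c(Cl)c4)ncnc3cc2OC)CC1` is not yet measured. Relative to compound 3 it carries methyl in place of hydrogen on a saturated chain carbon, ten or more bonds along the chain from an oxygen next to a carbonyl group. This is the same kind of change as that from compound 1 to compound 2, but at a different place along the chain, as the two descriptions of the changes show. The two cores differ by hexyl in place of hydrogen on a saturated chain carbon, nine bonds along the chain from an oxygen next to a carbonyl group.

Since the same kind of change gave a number 5.7 percentage points higher from compound 1 to compound 2 (within the scatter) from compound 1 to compound 2, a step of similar size, within the scatter, is expected here: a number 1 percentage points higher from compound 3 to compound 4 (within the scatter). With all three measured numbers of this assay close together, compound 4 is estimated at 93%, expected between 84% and 101%.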

Compound 4, a percentage reported as activity, at one concentration (the size of the read-out at that concentration, not a potency): 97.7%
Estimate against measurement, compound 4: 4.7 percentage points below; the measured number falls inside the stated range.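

In this assay, methyl in place of hydrogen on a saturated chain carbon, ten or more bonds along the chain from an oxygen next to a carbonyl group, gives a number 5.7 percentage points higher from compound 3 to compound 4 (within the scatter), and the same kind of change on the core of compound 1 reads alike: the same change on two cores in this assay, a number 5.7 percentage points higher (within the scatter) from compound 1 to compound 2 and a number 5.7 percentage points higher (within the scatter) from compound 3 to compound 4, 0 percentage points apart, within the scatter of two such steps. The heptyl change gives a number 7.7 percentage points higher from compound 1 to compound 4 (within the scatter), and the hexyl change gives a number 2 percentage points higher from compound 2 to compound 4 (within the scatter), which agrees with the hexyl change on the other core: the same change on two cores in this assay, a number 2 percentage points higher (within the scatter) from compound 1 to compound 3 and a number 2 percentage points higher (within the scatter) from compound 2 to compound 4, 0 percentage points apart, within the scatter of two such steps. Among the compounds shown here, since every one of these steps lies within the scatter, the agreement shows only that these chain changes carry from one core to another without a step that can be told from scatter; it does not show a real effect that transfers, and it gives no order among the four compounds and no trend with chain length.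

All four compounds shown carry an unbranched saturated chain on the ester of the shared core, so whether any change to that chain can move this read-out beyond the scatter stays open. A branched chain, a chain ending in an amine, or a free carboxylic acid in place of the ester would address that question, as would readings at other concentrations.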